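This account rests on a few compounds, and the source may have more. Where it says the series, first, only, none or still open, it means among the compounds named here.

Measured compounds:
compound 1, `Cc1csc2cc([C@H](C)Nc3ncnc(N)c3C#N)c(-c3cccc(CN(C)CCCN(C)Cc4ccc(Cl)cc4)c3)c(=O)n12`, 13 h
compound 2, `Cc1csc2cc([C@H](C)Nc3ncnc(N)c3C#N)c(Cc3cccc(CN(C)CC(C)C)c3)c(=O)n12`, 2.3 h

Among the compounds with values here, in an ADME assay on the whole organism (lung, Rattus norvegicus) for metabolic stability, read by LC-MS (on this read-out lower numbers stand for a shorter-lived compound and higher numbers for a longer-lived compound), compound 2 stands at the lower of the two numbers so far. Compound 1 sits well apart from it, and since the two differ in more than one place, the gap between them shows only what the two values show, not what any single change does. Compound 3, `Cc1csc2cc([C@H](C)Nc3ncnc(N)c3C#N)c(Cc3cccc(CN4CCC4)c3)c(=O)n12`, has not yet been measured in this assay. It differs from compound 2 in one place: azetidin-1-yl in place of isobutyl(methyl)amino on a saturated chain carbon bound to an aromatic carbon. Within the data shown here, no measured pair shows the effect of this kind of swap, so the direction of the step is uncertain. The step from compound 2 to compound 3 in this assay is expected to be small, likely within the usual scatter, so that a 1.1-fold higher number from compound 2 to compound 3 (0.04 log units; within the scatter) is estimated. On that basis compound 3 is expected to give about 2.5 h, with a range from 1 h to 6 h.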

Compound 3, half-life: 1.1 h
For compound 3 the middle estimate is 2.3-fold (0.36 log units) above the measured one; the measured number falls inside the stated range.
By their numbers in this assay, from the lowest: compound 3; then compound 2; then compound 1.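

In this assay, putting azetidin-1-yl in place of isobutyl(methyl)amino on a saturated chain carbon bound to an aromatic carbon gives a 2.1-fold lower number from compound 2 to compound 3 (0.32 log units; beyond the scatter). Within the data shown here, this is the first comparison here that changes only one place, and it shows that the half-life responds to the amine held at this carbon, even though the rest of the structure stays the same. The step is modest, and no accompanying measurement says why the number moves in this direction.

This single swap changes both the size of the group and whether it contains a ring, so it cannot show which of the two goes with the shorter half-life; dimethylamino or pyrrolidin-1-yl at the same place could help pull them apart. As far as these compounds go, it also remains open whether the same swap would give a step of similar size on a different core or side chain, such as those in compound 1.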